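A few compounds are considered here, and "the series" means these few. Any claim that something is new, unique, unknown or untested is made for them only; others in the source may bear on it.

Of the compounds shown here, two have been measured in an assay on microsomes from liver for inhibition of acyl-CoA desaturase 1 (Rattus norvegicus); on this read-out lower numbers stand for stronger inhibition and higher numbers for weaker inhibition. Compound 1 `CC(C)(C)c1nnc(-c2ccc(N3CCC(Oc4ccccc4C(F)(F)F)CC3)nn2)s1` gives 710 nM in this assay, which is the higher of the two numbers. Going by the values given here, compound 2 `c1cc(OC2CCN(c3ccc(-n4ccnc4)nn3)CC2)c2cc[nH]c2c1` gives 162 nM in this assay, a lower number that lies beyond the usual scatter of repeated measurements; the two structures differ in several places at once, so the pair shows only that compound 2 inhibits more strongly, not which part of the difference is responsible.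

Compound 3 `CC(C)Cc1nnc(-c2ccc(N3CCC(Oc4ccccc4C(F)(F)F)CC3)nn2)o1` has not yet been measured. It differs from compound 1 in one place: 5-isobutyl-1,3,4-oxadiazol-2-yl in place of 5-(tert-butyl)-1,3,4-thiadiazol-2-yl on an aromatic carbon. The rest of the molecule, including the shared core and the ether-linked ring carrying the trifluoromethyl group, is unchanged. Among the compounds with values here, no measured pair in this set isolates such a swap, so there is no direct guide to how large an effect to expect. The expectation is a step from compound 1 to compound 3 of a 1.1-fold higher number from compound 1 to compound 3 (0.05 log units; within the scatter), which could fall either within or slightly beyond the scatter. Compound 3 is therefore estimated at 800 nM in this assay, with a plausible range from 250 nM to 2500 nM.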

Compound 3, half-maximal inhibitory concentration: 15 nM
Beside the measured number, compound 3's estimate is 53-fold (1.73 log units) above it; measured number below the stated range.
By their numbers in this assay, from the lowest: compound 3; then compound 2; then compound 1.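

In this assay, this position on an aromatic carbon, next to the ring nitrogen and para to a large group, proves highly sensitive: exchanging 5-(tert-butyl)-1,3,4-thiadiazol-2-yl for 5-isobutyl-1,3,4-oxadiazol-2-yl gives a 47-fold lower number from compound 1 to compound 3 (1.68 log units; beyond the scatter) with the rest of the molecule unchanged. The earlier pair differed in several places at once, whereas this single swap ties a large step to one place. The two groups have the same counts of heavy atoms, hydrogen-bond donors and hydrogen-bond acceptors, so those counts do not distinguish them, and nothing available here explains the size of the step.

The swap changes both the ring, with oxygen replacing sulfur, and the chain, with isobutyl replacing tert-butyl, so the compounds shown leave open which change carries the step, a question that 5-isobutyl-1,3,4-thiadiazol-2-yl at this position could help to settle. Going by these compounds, it also remains open how far the trend extends along the chain on the oxadiazole ring, for example with a longer chain such as n-hexyl or with an amine at its end.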